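The source may hold more compounds than are shown below. What is called first, only, known or untested is meant among the compounds shown, and "the series" means these compounds.

Of the compounds shown here, three from the series have been tested in a functional assay on HL-60 cells (Homo sapiens) for antiproliferative activity, read by MTT assay; on this read-out lower numbers stand for stronger inhibition and higher numbers for weaker inhibition. Compound 1 `OC[C@H]1O[C@@H](Cc2ccccc2)[C@H](O)[C@@H](OCc2ccccc2)[C@@H]1OCc1ccccc1` gives 20200 nM in this assay. Compound 2 `CCCC[C@@H]1O[C@H](COCc2ccccc2)[C@@H](OCc2ccccc2)[C@H](OCc2ccccc2)[C@H]1O` is recorded in this assay as "not active" (no number reported), with no number. Compound 3 `CCC[C@@H]1O[C@H](CO)[C@@H](O)[C@H](O)[C@H]1O` is likewise reported in this assay as "not active" (no number reported). Compound 2 therefore stands without a numerical value, alongside one further compound in the same position; only compound 1 carries a number. Compound 4 `C=C[C@@H]1O[C@H](COCc2ccccc2)[C@@H](OCc2ccccc2)[C@H](OCc2ccccc2)[C@H]1O` remains to be measured; it differs from compound 2 in one place: vinyl in place of butyl on a saturated ring carbon. Within the data shown here, no measured pair shows this change, so the step is expected to be small, within the scatter, without a clear direction. Compound 4 is expected to give 40000 nM in this assay, in the range 12000 nM to 150000 nM, with a sizeable chance that again no number results.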

Compound 4, half-maximal inhibitory concentration: 11800 nM
Compound 4: the middle estimate sits 3.4-fold (0.53 log units) above what was measured; the whole stated range lies above it.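

Among these compounds, compound 2 has no number in this assay and so no step to compound 4 can be read. Nothing at hand accounts for the value of compound 4. Left open is how vinyl and butyl compare in this assay on the shared core.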